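The source may hold more compounds than are shown below. What is called first, only, known or untested is meant among the compounds shown, and "the series" means these compounds.

Measured so far:
Compound 1 `CC(=O)CCc1cc(C)c(Oc2cc(Nc3ccc(C#N)cc3)c(N)cc2C(F)(F)F)c(C)c1`: 11100 nM
Compound 2 `Cc1cc(/C=C/C#N)cc(C)c1Oc1cc(Nc2ccc(C#N)cc2)c(N)cc1[N+](=O)[O-]`: > 24400 nM

In an ADME assay on TZM cells (Homo sapiens) for cytotoxicity, read by XTT assay, with a stated time of 4 days (a higher number here means that more compound is tolerated, a lower number that less compound is tolerated), compound 2 gives > 24400 nM, and this is a limit of the assay, not a number. Compound 3 `CNC(=O)c1cc(N)c(Nc2ccc(C#N)cc2)cc1Oc1c(C)cc(/C=C/C#N)cc1C` carries methylcarbamoyl in place of nitro on an aromatic carbon, para to a (4-cyanophenyl)amino group (methylcarbamoyl in place of nitro on an aromatic carbon). Among the measured compounds shown here, no measured pair shows what such a change does. For the measured compounds named here, the only true number comes from compound 1, at 11100 nM, so a modest downward move is expected rather than a large one. The expected move in this assay is an at least 1.5-fold lower number from compound 2 to compound 3 (0.18 log units; that floor lies within the scatter). For compound 3 the estimated value is 16000 nM, with an expected range of 7000 nM to 30000 nM.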

Compound 3, half-maximal cytotoxic concentration: > 9200 nM
Compound 3 was reported as a limit; the forecaster's own chance of this, stated with the estimate: 40%; the middle value lies beyond the limit too.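

In this assay, among the compounds shown here, compound 2 and compound 3 both give limits of the assay, not numbers, so no step between them can be read. Going by these compounds, what methylcarbamoyl in place of nitro does here remains open.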